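Swapping Sulfur for Oxygen on a Fused Diamine Core

The source may report more compounds than this note shows. Statements on the series, on what has been measured and on what is new or still open speak of the compounds shown alone.

Compound 3 `Nc1cc(N)c2nc(-c3ccccc3)c(Sc3ccc(F)cc3)nc2c1` carries a (4-fluorophenyl)sulfanyl group on the shared core. In a functional assay on MCF7 cells (Homo sapiens) for inhibition, read by sulforhodamine B assay, with a stated time of 48 h (a lower number here means that less compound is tolerated, a higher number that more compound is tolerated), compound 3 gives < 100000 nM, which is a limit of the assay rather than a measured number. Compound 1 `Nc1cc(N)c2nc(-c3ccccc3)c(Oc3ccc(Cl)c(Cl)c3)nc2c1` gives < 100000 nM in this assay, again a limit. Compound 2 `Nc1cc(N)c2nc(-c3ccccc3)c(NCc3ccc(Cl)c(Cl)c3)nc2c1` gives < 100000 nM in this assay, also a limit. For the measured compounds named here, all three values sit at the limit of < 100000 nM in this assay, at which 3 of the 3 values shown sit, so no compound can be ranked above or below another. Going by the values given here, the only one-place step among them, a step that the two limits leave unreadable from compound 1 to compound 3, has no readable size for the same reason.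

Compound 4 `Nc1cc(N)c2nc(-c3ccccc3)c(Oc3ccc(F)cc3)nc2c1` differs from compound 3 in one place: 4-fluorophenoxy in place of (4-fluorophenyl)sulfanyl on an aromatic carbon. Among the compounds with values here, the sole measured step touching this position, a step that the two limits leave unreadable from compound 1 to compound 3, gives no readable size, so no direction beyond the usual scatter can be expected in this assay. Compound 4 is therefore expected to give about 30000 nM, with a range from 3000 nM to 100000 nM. The step this estimate means, a step that the limit leaves unreadable from compound 3 to compound 4, is expected to stay within the scatter, most likely ending again at the limit.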

Compound 4, concentration lethal to 50% of the cells: < 100000 nM
Compound 4 gave a limit, no number; the forecaster's own chance of this, stated with the estimate: 70%; the middle value is on the limit's open side.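

Compound 4 gives only a limit, as do compound 1 and compound 3, so neither new step ending at compound 4 can be read: the limit of < 100000 nM in this assay, at which 4 of the 4 values shown sit.

The compounds shown leave open whether 4-fluorophenoxy, (4-fluorophenyl)sulfanyl and 3,4-dichlorophenoxy differ at all in this assay.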